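Methoxy to phenoxy under a cytotoxicity read-out, two cores

The source may hold more compounds than are shown below. What is called first, only, known or untested is meant among the compounds shown, and "the series" means these compounds.

Compound 1 `CCOC(=O)c1c(-c2cccc(OC)c2)[nH]c2cc(F)cc(F)c2c1=O` is the reference on the first core. In an ADME assay on HEK293 cells (Homo sapiens) for cytotoxicity, read by luminescence, with a stated time of 72 h (on this read-out lower numbers stand for an effect already at smaller amounts and higher numbers for an effect only at larger amounts of compound), compound 1 gives > 22000 nM, which is a limit of the assay and not a number. Compound 2 `CCOC(=O)c1c(-c2cccc(Oc3ccccc3)c2)[nH]c2cc(F)cc(F)c2c1=O` carries phenyl in place of methyl on an oxygen on an aromatic ring. In this assay compound 2 gives > 22000 nM, again a limit. The step that the two limits leave unreadable from compound 1 to compound 2 cannot be sized. Compound 3 `CCOC(=O)c1c(-c2cccc(OC)c2)[nH]c2cc(Cl)c(OC)cc2c1=O` sits on a second core; the difference between the two cores is not broken down here. In this assay compound 3 gives > 22000 nM, also a limit. All values shown sit at the limit of > 22000 nM in this assay, at which 3 of the 3 values shown sit.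

Compound 4 `CCOC(=O)c1c(-c2cccc(Oc3ccccc3)c2)[nH]c2cc(Cl)c(OC)cc2c1=O` is not yet measured and carries phenyl in place of methyl on an oxygen on an aromatic ring, the same change as in the first pair, at the same place. For this assay a step that the limit leaves unreadable from compound 3 to compound 4 is expected, resting on the unreadable step that the two limits leave unreadable from compound 1 to compound 2 and on (the limit of > 22000 nM in this assay, at which 3 of the 3 values shown sit), which leaves no sign of an effect within the tested range. Compound 4 is expected to give 30000 nM, estimated between 15000 nM and 80000 nM, most likely reported as a limit again.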

Compound 4, half-maximal effective concentration: > 22000 nM
Compound 4: a limit, no number; the forecaster's own chance of this, stated with the estimate: 85%; the middle value is on the limit's open side.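

In this assay compound 4 gives > 22000 nM, a limit of the assay and not a number. No step can be read for methoxy to phenoxy, either between compound 3 and compound 4 or between compound 1 and compound 2: the limit of > 22000 nM in this assay, at which 4 of the 4 values shown sit.

The compounds shown leave open at what concentration, if any, cytotoxicity appears, and whether methoxy and phenoxy differ there.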